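The source may report more compounds than this note shows. Statements on the series, on what has been measured and on what is new or still open speak of the compounds shown alone.

Two compounds have so far been measured in a functional assay on RAW264.7 cells (Mus musculus) for inhibition, read by Griess assay, with stated times of 2 h and 18 h; a higher number here means a weaker inhibitor, a lower number a stronger inhibitor:

Compound 1 `CCC(=O)[C@H]1O[C@@](CCC2=CC(OC)OC2=O)(OC)[C@@]2(C)CCCC(C)(C)[C@H]12` gives 3900 nM.
Compound 2 `CCC(=O)[C@H]1O[C@@](CCC2=CCOC2=O)(OC)[C@@]2(C)CCCC(C)(C)[C@H]12` gives 21900 nM.

Among the measured compounds shown here, compound 2 stands at the higher of the two numbers, and so is the weaker inhibitor of the pair; the single measured step, a 5.6-fold higher number from compound 1 to compound 2 (0.75 log units; beyond the scatter), is what separates it from compound 1.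

Compound 3 `CCC(=O)[C@H]1O[C@@](CCc2ccoc2)(OC)[C@@]2(C)CCCC(C)(C)[C@H]12` differs from compound 2 by a group of 5 heavy atoms (4 carbon, 1 oxygen; one five-membered aromatic ring with 1 hetero atom) in place of a group of 6 heavy atoms (4 carbon, 2 oxygen; one five-membered non-aromatic ring with 1 hetero atom), on a saturated chain carbon, two bonds along the chain from a saturated ring carbon. For the measured compounds named here, the one step measured, a 5.6-fold higher number from compound 1 to compound 2 (0.75 log units; beyond the scatter), concerned a change on the very ring that now leaves, so it shows that this part of the molecule matters in this assay, but it says nothing about exchanging that ring for a different one. Going by the values given here, no measured step speaks to the change itself, so the expectation can only be anchored to the value of compound 2 and given a wide range; the expected step is a 1.1-fold higher number from compound 2 to compound 3 (0.06 log units; within the scatter), which is not expected to reach beyond the scatter in either direction with any confidence. Compound 3 is estimated at 25000 nM, with a range from 7000 nM to 90000 nM.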

Compound 3, half-maximal inhibitory concentration: > 50000 nM
Compound 3: only a limit was reported; the forecaster's own chance of this, stated with the estimate: 20%; at least 2.0-fold (0.30 log units) between middle value and limit.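

In this assay, replacing the five-membered non-aromatic ring with furan-3-yl, on a saturated chain carbon two bonds along the chain from a saturated ring carbon, gives an at least 2.2-fold higher number from compound 2 to compound 3 (0.35 log units; beyond the scatter). Measured against the ring that also carries the methoxy group, the same exchange gives an at least 12-fold higher number from compound 1 to compound 3 (1.10 log units; beyond the scatter), so the identity of the whole ring at this place matters in this assay, and not only the methoxy group on it, which was all the earlier step could speak to. Compound 3 has only a limit rather than a number, so both steps give a smallest size and no upper bound: the limit of > 50000 nM in this assay, at which 1 of the 3 values shown sits.

The compounds shown leave open which feature of the non-aromatic ring counts. Furan-3-yl differs from it in several ways at once, including the loss of the carbonyl and the change to an aromatic ring. A saturated tetrahydrofuran ring or an open-chain carboxylic acid at this place could help separate those features, while a hydroxyl or ethoxy group in place of the methoxy would show how far the gain seen with compound 1 extends.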